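This account rests on a few compounds, and the source may have more. Where it says the series, first, only, none or still open, it means among the compounds named here.

In a toxicity assay on CCRF-CEM cells (Homo sapiens) for cytotoxicity (on this read-out higher numbers stand for lower toxicity in this test and lower numbers for higher toxicity in this test), the series begins with compound 1 `Cc1cccc2c1nc(-c1c(F)cccc1F)n2Cc1c(F)cccc1F`. For compound 1 the result in this assay is only a limit of the assay, > 100 uM. Compound 2 `CC(=O)Nc1cccc2c1nc(-c1c(F)cccc1F)n2Cc1c(F)cccc1F` carries an acetamido in place of the methyl on an aromatic carbon, and in this assay compound 2 gives 39.3 uM. That makes the step of an at least 2.5-fold lower number from compound 1 to compound 2 (0.40 log units; beyond the scatter), with one of the two values sitting at the limit of the assay (the limit of > 100 uM in this assay, at which 1 of the 2 values shown sits). Going by the values given here, compound 2 therefore holds the only real number on record in this assay; the other value is a limit.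

Compound 3 `NCc1cccc2c1nc(-c1c(F)cccc1F)n2Cc1c(F)cccc1F` differs from compound 2 at a single site: aminomethyl in place of acetamido on an aromatic carbon. Among the compounds with values here, the one measured step, from compound 1 to compound 2, exchanged a methyl for an acetamido, not an acetamido for an aminomethyl, so it bears only loosely on this change. Nothing measured here points to a large move in either direction. For compound 3 the estimate in this assay is 30 uM, expected to fall between 10 uM and 100 uM, a step of a 1.3-fold lower number from compound 2 to compound 3 (0.12 log units; within the scatter) that is expected to stay near the scatter.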

Compound 3, half-maximal toxic concentration: 49.3 uM
Estimate against measurement, compound 3: 1.6-fold (0.22 log units) below, within the range that was stated.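

In this assay, swapping the acetamido for the aminomethyl on this aromatic carbon gives a 1.3-fold higher number from compound 2 to compound 3 (0.10 log units; within the scatter), so the two groups cannot be told apart in this test, even though the aminomethyl has 2 heavy atoms against 4 and lacks the double bond outside the aromatic rings. Placing amino in place of hydrogen on the saturated chain carbon gives an at least 2.0-fold lower number from compound 1 to compound 3 (0.30 log units; that floor lies within the scatter), so this floor alone does not establish a change beyond the scatter, although compound 3 does give a real number, as compound 2 does. Compound 1 gives only a limit of the assay, so the true size of that step remains unknown: the limit of > 100 uM in this assay, at which 1 of the 3 values shown sits.

Going by these compounds, whether other groups on this aromatic carbon, such as a carboxylic acid, a hydroxymethyl or a longer aminoalkyl chain, would stay in the same range remains open. On these data alone, it is also open whether a plain amine bonded directly to the aromatic carbon would behave like the aminomethyl, or whether the similarity between these two groups would hold on a different core.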